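This account rests on a few compounds, and the source may have more. Where it says the series, first, only, none or still open, it means among the compounds named here.

Working notes on the series. Going by the values given here, in a functional assay on M14 cells (Homo sapiens) for inhibition, read by sulforhodamine B assay, with a stated time of 48 h (on this read-out higher numbers stand for weaker inhibition of growth and lower numbers for stronger inhibition of growth), compound 3 `COc1cc(-c2nn(-c3cccc(NC(=O)Nc4ccc(Cl)c(C(F)(F)F)c4)c3)cc2-c2ccncc2)ccc1Cl` gives 1080 nM, the second highest of the three numbers so far. Compound 1 `COc1cc(-c2nn(-c3cccc(NC(=O)Nc4cccc(C(F)(F)F)c4)c3)cc2-c2ccncc2)ccc1Cl` gives 754 nM, and compound 2 `COc1cc(-c2nn(-c3cccc(NC(=O)c4ccc(Cl)c(C(F)(F)F)c4)c3)cc2-c2ccncc2)ccc1Cl` gives 2790 nM. Compound 4 `COc1cc(-c2nn(-c3cccc(NC(=O)c4ccccc4)c3)cc2-c2ccncc2)ccc1Cl` differs from compound 3 by phenyl in place of (4-chloro-3-(trifluoromethyl)phenyl)amino on a carbonyl carbon. Among the compounds with values here, two measured steps bear on this. The step of a 2.6-fold lower number from compound 2 to compound 3 (0.41 log units; beyond the scatter) shows what replacing the aryl on the carbonyl carbon with the corresponding arylamino did; the reverse direction is part of the change to compound 4. The step of a 1.4-fold higher number from compound 1 to compound 3 (0.16 log units; within the scatter) concerns only the chloro and stays within the scatter. Within the data shown here, no measured pair isolates the loss of the trifluoromethyl. Compound 4 is therefore expected to show a modest rise, a 3.2-fold higher number from compound 3 to compound 4 (0.51 log units; beyond the scatter), with the estimate 3500 nM and range 1200 nM to 10000 nM.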

Compound 4, concentration for 50% growth inhibition: 575 nM
Beside the measured number, compound 4's estimate is 6.1-fold (0.78 log units) above it, outside the stated range (below it).
By their numbers in this assay, from the lowest: compounds 4, 1 and 3 (each within the scatter of the next); then compound 2.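

Phenyl on the carbonyl carbon gives up nothing measurable against the arylamino groups in this assay: compound 4 sits within the scatter of both (a 1.9-fold lower number from compound 3 to compound 4 (0.27 log units; within the scatter); a 1.3-fold lower number from compound 1 to compound 4 (0.12 log units; within the scatter)), so neither the amide-type link to a second aryl nor its trifluoromethyl is required for this level of growth inhibition. Against the 4-chloro-3-(trifluoromethyl)phenyl group on the same carbon, phenyl gives the clear gain (a 4.9-fold lower number from compound 2 to compound 4 (0.69 log units; beyond the scatter)). Still open, from the compounds shown here alone, is how an amine or a carboxylic acid on that phenyl, or a longer chain in its place, would read. No evidence on the cause of these differences is available here.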